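The source may report more compounds than this note shows. Statements on the series, on what has been measured and on what is new or still open speak of the compounds shown alone.

Compound 1 `Cn1ccc(-c2ccc(Cn3cc(C(=O)N[C@H]4CCCC[C@@H]4O)c4ncccc43)cc2)n1` and compound 2 `Cn1ccc(-c2ccc(Cn3cc(C(=O)N[C@H]4CCOC[C@@H]4O)c4ncccc43)cc2)n1` share one core and differ only in the ring attached to the amide nitrogen. In an ADME assay on liver for metabolic stability, with Liver microsome (Homo sapiens) as the target, using microsomes (a lower number here means slower removal, a higher number faster removal of the compound), compound 1 gives 47 mL/min/kg, the higher of the two numbers, while compound 2 gives 10.6 mL/min/kg. That step, a 4.4-fold lower number from compound 1 to compound 2 (0.65 log units; beyond the scatter), is modest but beyond the scatter. Compound 3 `O=C(N[C@H]1CCCC[C@@H]1O)c1cn(Cc2ccc(-n3cc(-c4ccncc4)cn3)cc2)c2cccnc12` keeps the 2-hydroxycyclohexyl amide of compound 1 and instead alters the far end of the molecule: 4-(pyridin-4-yl)-1H-pyrazol-1-yl in place of 1-methyl-1H-pyrazol-3-yl on an aromatic carbon. Going by the values given here, the one measured step concerns the amide-side ring and not this position, so it gives no direct guide to the change made in compound 3. With nothing measured at this position, the expectation is no step beyond the scatter in this assay, and compound 3 is estimated at 40 mL/min/kg, with a likely range from 15 mL/min/kg to 100 mL/min/kg. The expected change is a 1.2-fold lower number from compound 1 to compound 3 (0.07 log units; within the scatter).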

Compound 3, clearance: 140 mL/min/kg
Estimate against measurement, compound 3: 3.5-fold (0.54 log units) below, outside the stated range (above it).
By their numbers in this assay, from the lowest: compound 2; then compound 1; then compound 3.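

The far end of the molecule also affects the number in this assay, with a 3.0-fold higher number from compound 1 to compound 3 (0.47 log units; beyond the scatter) when 4-(pyridin-4-yl)-1H-pyrazol-1-yl replaces 1-methyl-1H-pyrazol-3-yl. Until now, only the amide-side ring had been seen to shift this number, and that change went the other way, with a 4.4-fold lower number from compound 1 to compound 2 (0.65 log units; beyond the scatter). Nothing measured here points to a cause for the rise at the far end.

This swap changes both the way the pyrazole is attached and the presence of a pyridine ring, so the compounds shown cannot separate the two, and a simple methyl or phenyl group on the same 1H-pyrazol-1-yl ring could help to do so. Going by these compounds, it also remains open whether the 3-hydroxyoxan-4-yl amide would still give a lower number when paired with the 4-(pyridin-4-yl)-1H-pyrazol-1-yl group.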